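The source may hold more compounds than are shown below. What is called first, only, known or untested is meant among the compounds shown, and "the series" means these compounds.

Compound 1 `Cn1c(=O)c(S(=O)(=O)c2ccc(Cl)cc2Cl)cc2cnc(Nc3ccc4[nH]ccc4c3)nc21` gives 1000 nM in a functional assay on K562 cells (Homo sapiens) for inhibition, read by trypan blue exclusion, with a stated time of 72 h; on this read-out higher numbers stand for weaker inhibition and lower numbers for stronger inhibition.
Compound 2 `COc1ccc(S(=O)(=O)c2cc3cnc(Nc4cccc5[nH]ccc45)nc3n(C)c2=O)cc1` gives 5000 nM in this assay.

Of the two measured compounds, compound 1 stands lowest, and the gap to compound 2 lies beyond the scatter. Compound 3 `Cn1c(=O)c(S(=O)(=O)Nc2ccc(F)cc2)cc2cnc(Nc3ccc4[nH]ccc4c3)nc21` has not been measured. It differs from compound 1 in one place: (4-fluorophenyl)amino in place of 2,4-dichlorophenyl on a sulfonyl sulfur. Going by the values given here, no pair of measured compounds shows this kind of change, so the direction of the step from compound 1 to compound 3 cannot be read off any measured pair and rests on expectation alone. A step of this size, exchanging the group on the sulfonyl sulfur and adding a hydrogen-bond donor, is expected to move the number modestly, most likely upward, so that a 2.0-fold higher number from compound 1 to compound 3 (0.30 log units; within the scatter) is estimated as a weakening that may or may not exceed the scatter. Compound 3 is therefore expected to give about 2000 nM in this assay, with a likely range from 500 nM to 8000 nM.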

Compound 3, half-maximal inhibitory concentration: 5000 nM
Compound 3: middle estimate off by 2.5-fold (0.40 log units), on the low side; the range from low to high includes it.
By their numbers in this assay, from the lowest: compound 1; then compounds 2 and 3 (each within the scatter of the next).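

In this assay, the group on the sulfonyl sulfur proves able to shift the number beyond the scatter: (4-fluorophenyl)amino in place of 2,4-dichlorophenyl gives a 5.0-fold higher number from compound 1 to compound 3 (0.70 log units; beyond the scatter). Going by these compounds alone, this is the first comparison in the set that isolates a change in one place, and it places the change at the sulfonyl sulfur, with the rest of the core of compound 1 held constant. Nothing measured here offers an explanation for this step.

The compounds shown leave open whether the step follows from the amino link or from the exchange of the chlorines for a fluorine, as these two differences arrive together. Also open, going by these compounds, is how a morpholine, a piperazine or a short alkyl chain on the sulfonyl sulfur would compare with compound 1.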